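A few compounds are considered here, and "the series" means these few. Any claim that something is new, unique, unknown or untested is made for them only; others in the source may bear on it.

Of the compounds shown here, two built on a shared core have numbers so far. In a functional assay on KBVIN cells (Homo sapiens) for antiproliferative activity, read by sulforhodamine B assay, with a stated time of 3 days (a higher number here means that more compound is needed for the effect, a lower number that less compound is needed), compound 1 (`CCOc1ccc(-c2cc(=O)c3c(o2)C(CC)(CC)C(=O)C(CC)=C3O)cc1`) gives 7.54 uM and compound 2 (`CCC1=C(O)c2c(oc(-c3cccc(OC(F)(F)F)c3)cc2=O)C(CC)(CC)C1=O`) gives 9.95 uM and these two values lie within the usual scatter of each other. Compound 3 (`CCC1=C(O)c2c(oc(-c3cccc(F)c3)cc2=O)C(CC)(CC)C1=O`) has not yet been measured. It differs from compound 2 by fluoro in place of trifluoromethoxy on an aromatic carbon, meta to a large group (fluoro in place of trifluoromethoxy on an aromatic carbon). Within the data shown here, no step between measured compounds shows what this exchange does, so the expectation remains loose. Only a small shift in this assay is expected, toward a slightly lower number and probably not beyond the scatter. The estimated change is a step of a 1.2-fold lower number from compound 2 to compound 3 (0.09 log units; within the scatter) in size. For compound 3 the expected value is 8 uM with an estimated range from 3.5 uM to 18 uM as its bounds.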

Compound 3, concentration for half-maximal effect: 3.09 uM
The estimate for compound 3 lay 2.6-fold (0.41 log units) above the measured number, outside the stated range (below it).
By their numbers in this assay, from the lowest: compound 3; then compounds 1 and 2 (each within the scatter of the next).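

In this assay, fluoro in place of trifluoromethoxy on the aromatic carbon meta to a large group gives a 3.2-fold lower number from compound 2 to compound 3 (0.51 log units; beyond the scatter), which shows that the number responds to the group at this position, something compound 1 and compound 2 could not show, since their values lie within the scatter of each other. Among these compounds, the exchange of 4-ethoxyphenyl for 3-fluorophenyl gives a 2.4-fold lower number from compound 1 to compound 3 (0.39 log units; beyond the scatter), so compound 3 stands apart from both of the earlier compounds, with steps of similar modest size. No measurement at hand accounts for either step.

On these data alone, what an amine, a chloro group or a plain hydrogen would do on this same aromatic carbon remains open. So does whether fluoro would give a similar number on another carbon of this ring.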